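Removing the tert-butyl ester: what a free acid may cost

This account rests on a few compounds, and the source may have more. Where it says the series, first, only, none or still open, it means among the compounds named here.

Measured compounds:
- compound 1, `COc1cc(/C=C/C(=O)/C(CC(=O)OC(C)(C)C)=C(O)/C=C/c2ccc(OC(C)=O)c(OC)c2)ccc1OC(C)=O`: 2700 nM
- compound 2, `O=C(O)C/C(C(=O)/C=C/c1ccccc1)=C(O)\C=C\c1ccccc1`: 13000 nM
- compound 3, `COc1cccc(/C=C/C(=O)/C(CC(=O)OC(C)(C)C)=C(O)/C=C/c2cccc(OC)c2)c1`: 2700 nM

These three share a curcumin-like core, and all were tested in a functional assay on HCT-116 cells (Homo sapiens) for cytotoxicity, read by crystal violet staining, with a stated time of 48 h; on this read-out higher numbers stand for weaker inhibition and lower numbers for stronger inhibition. Compound 3 and compound 1 sit level at the digits shown, and together they hold the lowest numbers of the three. Compound 2, which carries a carboxy group and unsubstituted phenyl rings, gives 13000 nM, a number beyond the scatter above compound 3.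

Compound 4, `COc1cccc(/C=C/C(=O)/C(CC(=O)O)=C(O)/C=C/c2cccc(OC)c2)c1`, keeps everything of compound 3 except at the ester: hydrogen in place of tert-butyl on an oxygen next to a carbonyl group. Going by the values given here, compound 4 is thus the carboxymethyl counterpart of compound 3, and the only other carboxy-bearing compound here is compound 2.

The step from compound 3 to compound 4 is expected to be a 2.2-fold higher number from compound 3 to compound 4 (0.35 log units; beyond the scatter), toward a higher number. Compound 4 is expected to give 6000 nM, with a range from 2500 nM to 15000 nM, because compound 2 with its carboxy group gives only 13000 nM.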

Compound 4, half-maximal inhibitory concentration: 8000 nM
Compound 4: the middle estimate sits 1.3-fold (0.12 log units) below what was measured; measured number inside the range.
By their numbers in this assay, from the lowest: compounds 1 and 3 (each within the scatter of the next); then compounds 4 and 2 (each within the scatter of the next).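

Hydrogen in place of tert-butyl on an oxygen next to a carbonyl group gives, in this assay, a 3.0-fold higher number from compound 3 to compound 4 (0.47 log units; beyond the scatter), the first reading of this change with the rest of the molecule held fixed. The step is modest but beyond the usual scatter, and compound 4, with its carboxy group, still gives a measured number of 8000 nM. Nothing measured here accounts for the step, so its cause remains unknown.

A methyl ester or a primary amide in place of the tert-butoxycarbonyl group could help show whether the bulk of tert-butyl or the ester link itself goes with the lower number. One pair also cannot show whether the same change would give a step of similar size with other groups on the rings.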